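This account rests on a few compounds, and the source may have more. Where it says the series, first, only, none or still open, it means among the compounds named here.

Compounds in this small set share one core and differ in the group on a saturated chain carbon bound to an aromatic carbon. In a functional assay on PC-3 cells (Homo sapiens) for antiproliferative activity, read by MTT assay, with a stated time of 48 h (on this read-out lower numbers stand for stronger inhibition and higher numbers for weaker inhibition), compound 1 `COc1ccc(CN(C(=O)Cn2cc(CSc3nnnn3C)nn2)c2cc(OC)c(OC)c(OC)c2)cc1` gives 10900 nM, compound 2 `COc1ccc(CN(C(=O)Cn2cc(Cn3ccc4ccccc43)nn2)c2cc(OC)c(OC)c(OC)c2)cc1` gives 2390 nM, and compound 3 `COc1ccc(CN(C(=O)Cn2cc(CNS(=O)(=O)c3ccc(C)cc3)nn2)c2cc(OC)c(OC)c(OC)c2)cc1` gives 12400 nM. Swapping (1-methyl-1H-tetrazol-5-yl)sulfanyl for ((4-methylphenyl)sulfonyl)amino gives a 1.1-fold higher number from compound 1 to compound 3 (0.06 log units; within the scatter), so these two stand level. Swapping 1H-indol-1-yl for that same group gives a 5.2-fold higher number from compound 2 to compound 3 (0.72 log units; beyond the scatter), which leaves compound 3 on the higher-number side of the indole compound.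

Among the compounds with values here, compound 4 `COc1ccc(CN(C(=O)Cn2cc(CNS(=O)(=O)c3ccc(Br)cc3)nn2)c2cc(OC)c(OC)c(OC)c2)cc1` alters only one spot on compound 3: bromo in place of methyl on an aromatic carbon. In words, this is bromo in place of methyl on an aromatic carbon, turning 4-methylphenyl into 4-bromophenyl. Within the data shown here, no measured step tests a change on this ring, so the evidence is indirect. Exchanging an entire group gave a 4.6-fold lower number from compound 1 to compound 2 (0.66 log units; beyond the scatter) at one extreme and a 1.1-fold higher number from compound 1 to compound 3 (0.06 log units; within the scatter) at the other. The largest such exchange, a 5.2-fold higher number from compound 2 to compound 3 (0.72 log units; beyond the scatter), was still modest, so this much smaller swap, starting from compound 3 at 12400 nM, is expected to give no step beyond the scatter in this assay, in either direction. The expected change is a 1.1-fold lower number from compound 3 to compound 4 (0.05 log units; within the scatter). For compound 4 the estimated value is 11000 nM, with an expected range of 5000 nM to 24000 nM.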

Compound 4, half-maximal inhibitory concentration: 12500 nM
The estimate for compound 4 lay 1.1-fold (0.06 log units) below the measured number; low and high end bracket the measured number.
By their numbers in this assay, from the lowest: compound 2; then compounds 1, 3 and 4 (each within the scatter of the next).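

In this assay, within the data shown here, the change of bromo in place of methyl gives a 1.0-fold higher number from compound 3 to compound 4 (0.00 log units; within the scatter) and is the first test of a change on this aromatic ring, para to a large group. Both compounds therefore stand level, and turning 4-methylphenyl into 4-bromophenyl leaves the read-out where it was. Among these compounds, the standing of the sulfonylamino series also holds with the new ring group: there is a 5.2-fold higher number from compound 2 to compound 4 (0.72 log units; beyond the scatter) and so the indole compound keeps its lead, while a 1.1-fold higher number from compound 1 to compound 4 (0.06 log units; within the scatter) and so the tetrazole compound stays level, which means that within these compounds the only step beyond the scatter comes from exchanging the whole group on the chain carbon, and no measurement at hand explains why the ring swap leaves the number in place.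

Only methyl and bromo are shown at this ring position, so it remains open whether an amine, a carboxylic acid or a longer chain there would also leave the number in place. From the compounds shown here alone, it also remains open whether any group on this ring could bring the sulfonylamino series level with the indole compound.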